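The source may hold more compounds than are shown below. What is called first, only, known or untested is meant among the compounds shown, and "the series" means these compounds.

Compound 1 `CCCCC[Se]c1nc([Se]CCCCC)c2ccccc2n1` and compound 2 `CCCCC[Se]c1nc(NCc2ccccc2)c2ccccc2n1` share one core; in compound 2 a benzylamino group replaces one of the two identical chains of compound 1. In a functional assay on HT-29 cells (Homo sapiens) for cytotoxicity, read by MTT assay, with a stated time of 72 h (a higher number here means that more compound is tolerated, a lower number that less compound is tolerated), compound 1 gives only a limit of the assay, > 100000 nM. In this assay compound 2 likewise gives only a limit, > 100000 nM. The step that the two limits leave unreadable from compound 1 to compound 2 is thus unreadable, both values sitting at the limit of > 100000 nM in this assay, at which 2 of the 2 values shown sit. Compound 3 `CSc1nc(NCc2ccccc2)c2ccccc2n1` is the next member: a group of 2 heavy atoms (1 carbon, 1 sulfur; no ring) in place of a group of 6 heavy atoms (5 carbon, 1 selenium; no ring), on an aromatic carbon. Going by the values given here, no measured step bears directly on this exchange, and the only step on record, running from one limit to another, shows no size at all. The step from compound 2 to compound 3 is expected to be no larger than the scatter, a number no higher from compound 2 to compound 3 (the limit leaves the size open). The estimate for compound 3 in this assay is 100000 nM, within 30000 nM to 300000 nM, most likely returned again as a limit.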

Compound 3, concentration lethal to 50% of the cells: > 100000 nM
Compound 3 gave a limit, no number; the forecaster's own chance of this, stated with the estimate: 85%; the middle value lies on the limit itself.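

Compound 2 and compound 3 both return only limits in this assay, so no step between them can be read: the limit of > 100000 nM in this assay, at which 3 of the 3 values shown sit.

The compounds shown leave open whether any exchange on the shared core would give a readable value in this assay.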